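This account rests on a few compounds, and the source may have more. Where it says the series, first, only, none or still open, it means among the compounds named here.

Measured so far:
Compound 1 `O=C(Nc1ccc([N+](=O)[O-])cc1)N[C@H]1CC[C@H](Oc2ccc(F)cc2)CC1`: 2300 nM
Compound 2 `Cc1cccc(NC(=O)N[C@H]2CC[C@H](Oc3ccc(F)cc3)CC2)c1`: 14400 nM

In a functional assay on CRL2813 cells (Homo sapiens) for cytotoxicity, read by sulforhodamine B assay, with a stated time of 5 days (on this read-out higher numbers stand for weaker inhibition and lower numbers for stronger inhibition), compound 2 gives 14400 nM, the highest of the two numbers, so the weaker of the two. Within the data shown here, the only measured step leads to it: the number rises a 6.3-fold higher number from compound 1 to compound 2 (0.80 log units; beyond the scatter) when 3-methylphenyl replaces 4-nitrophenyl on the amide-type nitrogen. Compound 3 `O=C(Nc1cccc(C(=O)O)c1)N[C@H]1CC[C@H](Oc2ccc(F)cc2)CC1` differs from compound 2 by carboxy in place of methyl on an aromatic carbon. Among the measured compounds shown here, that step touches the same phenyl ring, but no measured pair shows what a carboxy group does there, so the single known step gives only a loose guide. Compound 3 is therefore expected to stay close to compound 2, with the step of a 1.0-fold higher number from compound 2 to compound 3 (0.02 log units; within the scatter) estimated to lie within or near the scatter in either direction. For compound 3 the estimated value in this assay is 15000 nM, with a wide range from 4000 nM to 60000 nM.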

Compound 3, half-maximal inhibitory concentration: > 20000 nM
Compound 3: no number, only a limit (the forecaster's own chance of this, stated with the estimate: 15%); middle value at least 1.3-fold (0.12 log units) away from the limit.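

In this assay compound 3 gives > 20000 nM, which is a limit of the assay and not a number, so the exact size of the change cannot be read: the limit of > 20000 nM in this assay, at which 1 of the 3 values shown sits. Carboxy in place of methyl on this ring gives an at least 1.3-fold higher number from compound 2 to compound 3 (0.14 log units; that floor lies within the scatter), so these two groups cannot yet be told apart here. The comparison with 4-nitrophenyl is clearer, with an at least 8.6-fold higher number from compound 1 to compound 3 (0.93 log units; beyond the scatter), which shows that 3-carboxyphenyl, like 3-methylphenyl, gives a clearly higher number than 4-nitrophenyl.

The compounds shown do not separate the effect of the nitro group itself from the effect of where it sits on the ring. They also leave open how an amine or a methyl ester would behave in place of the carboxy group.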